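Stripping the 4-pentylphenyl group from compound 2

The source may hold more compounds than are shown below. What is called first, only, known or untested is meant among the compounds shown, and "the series" means these compounds.

Compound 1, `Cc1ccc(-c2cn(C/C=C3\OC(=O)C(OCc4ccccc4)=C3OCc3ccccc3)nn2)cc1`: in a functional assay on MCF7 cells (Homo sapiens) for antiproliferative activity, read by MTT assay, with a stated time of 72 h (a lower number here means a stronger inhibitor, a higher number a weaker inhibitor), compound 1 gives > 100000 nM, a limit.
Compound 2, `CCCCCc1ccc(-c2cn(C[C@H](O)[C@H]3OC(=O)C(OCc4ccccc4)=C3OCc3ccccc3)nn2)cc1`: in this assay compound 2 gives 9010 nM.
Compound 3, `O=C1O/C(=C\Cn2cc(-c3cc(C(F)(F)F)cc(C(F)(F)F)c3)nn2)C(OCc2ccccc2)=C1OCc1ccccc1`: in this assay compound 3 gives > 100000 nM, a limit.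

Of the three measured compounds, compound 2 is the only one that returns an actual number. Compounds 1 and 3 each sit at the limit of the assay, (the limit of > 100000 nM in this assay, at which 2 of the 3 values shown sit), so compound 2 stands alone as the compound with measurable inhibition in this set.

Compound 4, `O=C1O[C@H]([C@@H](O)Cn2ccnn2)C(OCc2ccccc2)=C1OCc1ccccc1`, has not yet been measured. It differs from compound 2 in a single place: hydrogen in place of 4-pentylphenyl on an aromatic carbon. Among the measured compounds shown here, no pair of measured compounds differs in only one place, so there is no direct precedent for a change of this kind. For the measured compounds named here, what can be said is that compound 2, the one compound with a number, carries a large group on that ring carbon, and compound 4 carries none.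

Taking that away is a substantial change, and the expectation is a step toward weaker inhibition, a 5.5-fold higher number from compound 2 to compound 4 (0.74 log units; beyond the scatter). Compound 4 is therefore estimated at 50000 nM, with a likely range from 9000 nM to 200000 nM, and with a real chance that only a limit is recorded.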

Compound 4, half-maximal inhibitory concentration: > 100000 nM
Compound 4 ended at the assay's limit; the forecaster's own chance of this, stated with the estimate: 60%; middle value at least 2.0-fold (0.30 log units) from the limit.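

Among the compounds shown here, the first step that can be read in this assay falls at this position: putting hydrogen in place of 4-pentylphenyl on an aromatic carbon of the five-membered aromatic ring gives an at least 11-fold higher number from compound 2 to compound 4 (1.04 log units; beyond the scatter). Everything else in the structure stays the same across this step, so the measurable number of compound 2 depends on this group being present, which the earlier compounds, differing from one another in more than one place, could not show. The true size of the step remains unknown, and the printed figure is only a lower bound, because compound 4 gives only a limit rather than a number: the limit of > 100000 nM in this assay, at which 3 of the 4 values shown sit.

The step compares a large group with none at all, so it leaves open how much of 4-pentylphenyl is needed: a plain phenyl group, or a phenyl ring carrying a propyl chain, would separate the contribution of the ring from that of the chain. An amine or a carboxylic acid on the same aromatic carbon would show whether groups of a quite different kind can stand in its place.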